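A Trifluoromethoxy Swap in a Narrow Cytotoxicity Series

The compounds below may be only part of what the source reports. "The series", "measured", "known", "first", "only" and "open" are said of these compounds alone.

In an ADME assay on Vero cells (Chlorocebus sabaeus) for cytotoxicity, read by resazurin assay, with a stated time of 72 h (a lower number here means a stronger inhibitor, a higher number a weaker inhibitor), compound 1 (`Cc1ccc(C(=O)CCN2CCN(c3ccc(Cl)cc3)CC2)cc1`) gives 184000 nM, and its steps to both other measured compounds stay within the scatter. Compound 4 (`O=C(CCN1CCN(c2ccc(Cl)cc2)CC1)c1ccc(OC(F)(F)F)cc1`) has trifluoromethoxy in place of methyl on an aromatic carbon. Compound 2 (`Cc1ccc(C(=O)CCN2CCN(c3ccc([N+](=O)[O-])cc3)CC2)cc1`) gives 235000 nM, and nitro in place of chloro on an aromatic carbon makes a 1.3-fold higher number from compound 1 to compound 2 (0.11 log units; within the scatter). Compound 3 (`O=C(CCN1CCN(c2ccc(Cl)cc2)CC1)c1ccc(Cl)c(F)c1`) gives 175000 nM and bears more closely, since 4-chloro-3-fluorophenyl in place of 4-methylphenyl on a carbonyl carbon replaces the same methyl-bearing group, making a 1.1-fold lower number from compound 1 to compound 3 (0.02 log units; within the scatter). No step beyond the scatter is therefore expected in this assay. The expected change is a 1.1-fold lower number from compound 1 to compound 4 (0.05 log units; within the scatter). For compound 4 the estimated value is 165000 nM, with an expected range from 90000 nM to 280000 nM.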

Compound 4, half-maximal inhibitory concentration: 95600 nM
Compound 4: middle estimate off by 1.7-fold (0.24 log units), on the high side; the measured number falls inside the stated range.
By their numbers in this assay, from the lowest: compounds 4, 3, 1 and 2 (each within the scatter of the next, the first and the last beyond it).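

In this assay, trifluoromethoxy in place of methyl on an aromatic carbon, para to a large group, gives a 1.9-fold lower number from compound 1 to compound 4 (0.28 log units; within the scatter). Among these compounds, this position therefore accepts five heavy atoms, including a hydrogen-bond acceptor, in place of a single carbon without a step beyond the scatter, a single-group exchange that the earlier compounds did not show. No supporting evidence bears on this result. The compounds shown leave open whether an amine or a carboxylic acid on this aromatic carbon would give a step beyond the scatter.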